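The source may hold more compounds than are shown below. What is called first, only, known or untested is meant among the compounds shown, and "the series" means these compounds.

Compound 1 `COc1cc(/C=C/C(=O)/C=C/c2cccc3ccccc23)ccc1OCc1cn(CCCCCOc2cc(=O)oc3ccccc23)nn1` gives 44%
Compound 2 `COc1cc(/C=C/C(=O)/C=C/c2ccco2)ccc1OCc1cn(CCCCOc2cc(=O)oc3ccccc23)nn1` gives 49%

Both values come from a functional assay on THP-1 cells (Homo sapiens) for inhibition, read by sulforhodamine B assay, with a stated time of 48 h, tested at 50 uM; on this read-out higher numbers stand for more inhibition of growth at the one concentration tested and lower numbers for less inhibition of growth. Among the measured compounds shown here, compound 1 lies within the scatter of compound 2, the only other measured compound, so neither stands apart. Compound 3 `COc1cc(/C=C/C(=O)/C=C/c2cc(OC)c(OC)c(OC)c2)ccc1OCc1cn(CCCCCOc2cc(=O)oc3ccccc23)nn1` has 3,4,5-trimethoxyphenyl in place of naphthalen-1-yl on a double-bonded chain carbon bound to a double-bonded chain carbon. For the measured compounds named here, no measured pair isolates this change, so no step beyond the scatter is expected. The estimated a number 6 percentage points higher from compound 1 to compound 3 (within the scatter) stays within that scatter. In this assay the estimate for compound 3 is 50% (expected range 35% to 67%).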

Compound 3, percent growth inhibition at one concentration: 55%
Compound 3: middle estimate off by 5 percentage points, on the low side; measured number inside the range.
By their numbers in this assay, from the lowest: compounds 1, 2 and 3 (each within the scatter of the next, the first and the last beyond it).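

In this assay, putting 3,4,5-trimethoxyphenyl in place of naphthalen-1-yl on a double-bonded chain carbon bound to a double-bonded chain carbon gives a number 11 percentage points higher from compound 1 to compound 3 (beyond the scatter), a modest step. Among the compounds shown here, this is the first sign that the group at this place can shift growth inhibition, since the earlier compounds offered no single-change comparison. Nothing measured here explains the step.

Still open, going by these compounds, is whether the step follows from the three methoxy groups or from the change from two aromatic rings to one. A plain phenyl group at this place would help separate the two.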